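This account rests on a few compounds, and the source may have more. Where it says the series, first, only, none or still open, it means among the compounds named here.

Working notes on the series: in a functional assay on ES2 cells (Homo sapiens) for inhibition, read by MTT assay, with a stated time of 48 h (a lower number here means a stronger inhibitor, a higher number a weaker inhibitor), compound 1 (`O=C(CCCCCCOc1no[n+]([O-])c1S(=O)(=O)c1ccccc1)NO`) gives 7730 nM and compound 2 (`O=C(COCCOc1no[n+]([O-])c1S(=O)(=O)c1ccccc1)NO`) gives 8690 nM as the only two numbers so far. Compound 2 therefore sits within the scatter of compound 1. Compound 3 (`O=C(NO)OCCOCCOc1no[n+]([O-])c1S(=O)(=O)c1ccccc1`) differs from compound 2 by ((hydroxycarbamoyl)oxy)methyl in place of hydroxycarbamoyl on a saturated chain carbon bound to an oxygen on a saturated carbon and carries ((hydroxycarbamoyl)oxy)methyl in place of hydroxycarbamoyl on a saturated chain carbon bound to an oxygen on a saturated carbon. For the measured compounds named here, the one measured step that bears on this is a 1.1-fold higher number from compound 1 to compound 2 (0.05 log units; within the scatter) and it concerns the chain alone. Going by the values given here, no measured step alters the hydroxycarbamoyl end itself, so the guide is limited. No shift beyond the scatter is expected in this assay and the expected step is a 1.1-fold higher number from compound 2 to compound 3 (0.04 log units; within the scatter) in this estimate. For compound 3 the estimated value is 9500 nM with an expected range from 4500 nM to 20000 nM given the limited guide.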

Compound 3, half-maximal inhibitory concentration: 18100 nM
Estimate against measurement, compound 3: 1.9-fold (0.28 log units) below; measured number inside the range.
By their numbers in this assay, from the lowest: compounds 1 and 2 (each within the scatter of the next); then compound 3.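

In this assay, ((hydroxycarbamoyl)oxy)methyl in place of hydroxycarbamoyl on a saturated chain carbon bound to an oxygen on a saturated carbon gives a 2.1-fold higher number from compound 2 to compound 3 (0.32 log units; beyond the scatter), so this position does respond to a change at the chain end, though only modestly. Set against the 4-(hydroxycarbamoyl)butyl chain, 2-((hydroxycarbamoyl)oxy)ethoxy gives a 2.3-fold higher number from compound 1 to compound 3 (0.37 log units; beyond the scatter), whereas (hydroxycarbamoyl)methoxy stayed within the scatter at a 1.1-fold higher number from compound 1 to compound 2 (0.05 log units; within the scatter) and showed no such shift. Nothing on hand accounts for the higher number of compound 3.

As far as these compounds go, compound 3 changes chain length and the link to the hydroxycarbamoyl group together, so the share of each remains open. A longer ether chain ending in a carbon-bound hydroxycarbamoyl group would separate the two, and a carboxylic acid at the chain end would show how far this position depends on the hydroxycarbamoyl group itself.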